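From compound 3 to compound 4: a longer chain

The source may hold more compounds than are shown below. What is called first, only, known or untested is meant among the compounds shown, and "the series" means these compounds.

Measured in a functional assay on ECa-109 cells for antiproliferative activity against ECa-109 cell line (Homo sapiens), read by MTT assay, with a stated time of 48 h; a lower number here means a stronger inhibitor, a higher number a weaker inhibitor:
Compound 1 `COc1ccc(CN(C(=O)CSc2ccccn2)c2cc(OC)c(OC)c(OC)c2)cc1`: 16000 nM
Compound 2 `COc1ccc(CN(C(=O)CSC2=CN=NC2C)c2cc(OC)c(OC)c(OC)c2)cc1`: > 80000 nM (a limit of the assay)
Compound 3 `COc1ccc(CN(C(=O)CCSc2nc3ccccc3o2)c2cc(OC)c(OC)c(OC)c2)cc1`: 12600 nM

Going by the values given here, compound 3 and compound 1 lie within the scatter of each other, and together they hold the only two exact numbers in the set. Compound 2 gives only a limit of the assay.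

Compound 4 `COc1ccc(CN(C(=O)CCCCSc2nc3ccccc3o2)c2cc(OC)c(OC)c(OC)c2)cc1` is related to compound 3 by one change: 2-((1,3-benzoxazol-2-yl)sulfanyl)ethyl in place of (1,3-benzoxazol-2-yl)sulfanyl on a saturated chain carbon, two bonds along the chain from a carbonyl carbon. The ring group on the sulfur stays the same, and only the chain grows.

The two steps beyond the scatter, an at least 5.0-fold higher number from compound 1 to compound 2 (0.69 log units; beyond the scatter) and an at least 6.3-fold lower number from compound 2 to compound 3 (0.80 log units; beyond the scatter), both involve a change of the ring on the sulfur, which does not happen here, so they say little about this case. The closest guide is a 1.3-fold lower number from compound 1 to compound 3 (0.10 log units; within the scatter), which puts ((1,3-benzoxazol-2-yl)sulfanyl)methyl in place of (pyridin-2-yl)sulfanyl and stays within the scatter. Among the compounds with values here, no measured step changes the chain alone, so the guidance is thin.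

No step beyond the scatter is therefore expected in this assay, and the estimated change is a 1.1-fold lower number from compound 3 to compound 4 (0.02 log units; within the scatter). The expected value for compound 4 is 12000 nM, with an estimated range of 4000 nM to 35000 nM.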

Compound 4, half-maximal inhibitory concentration: 7650 nM
Estimate against measurement, compound 4: 1.6-fold (0.20 log units) above; measured number inside the range.
By their numbers in this assay, from the lowest: compounds 4, 3 and 1 (each within the scatter of the next, the first and the last beyond it). At a limit, above all of these: compound 2.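

Going by these compounds alone, the first step in this assay that alters the chain alone, with the ring group on the sulfur held the same, gives a 1.6-fold lower number from compound 3 to compound 4 (0.22 log units; within the scatter) and so leaves compound 3 and compound 4 not separable by this measurement. Within the data shown here, the place on a saturated chain carbon, two bonds along the chain from a carbonyl carbon, therefore accepts 2-((1,3-benzoxazol-2-yl)sulfanyl)ethyl in place of (1,3-benzoxazol-2-yl)sulfanyl without a step beyond the scatter, something the earlier compounds could not show, as each of their steps also altered the ring group on the sulfur. Nothing among the data shown bears on this particular step or offers an account of it.

The compounds shown leave open whether a still longer chain, or an amine or a carboxylic acid at the end of the chain, would give a step beyond the scatter in this assay. They also leave open whether an oxygen in place of the sulfur would be accepted in the same way, and whether the longer chain would give a similar result with a ring group other than 1,3-benzoxazol-2-yl on the sulfur.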